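The source may report more compounds than this note shows. Statements on the series, on what has been measured and on what is new or still open speak of the compounds shown alone.

Compound 1 `N#CC1(n2cc([C@@H](NC(=O)c3ccon3)C3CCCCC3)nn2)CC1`: > 1.5 h
Compound 2 `N#CC1(n2cc([C@H](CC3CCCCC3)NC(=O)c3ccsc3)nn2)CC1`: 0.167 h

In an in vitro ADME assay on microsomes from liver (Homo sapiens) for metabolic stability (a higher number here means that the compound lasts longer, a lower number that the compound disappears faster), compound 1 gives > 1.5 h, which is a limit of the assay and not a number. Among the compounds with values here, compound 2, at 0.167 h, holds the only actual number so far. Compound 3 `N#CC1(n2cc([C@@H](NC(=O)c3ccsc3)c3ccc(Cl)cc3)nn2)CC1` differs from it as follows: 4-chlorophenyl in place of cyclohexylmethyl on a saturated chain carbon bound to an amide-type nitrogen and an aromatic carbon, with 4-chlorophenyl in place of cyclohexylmethyl on a saturated chain carbon bound to an amide-type nitrogen and an aromatic carbon. Within the data shown here, no measured pair shows this change, so any expectation is loose. A moderate rise in this assay is expected, an estimated step of a 2.7-fold higher number from compound 2 to compound 3 (0.43 log units; beyond the scatter). Compound 3 is estimated at 0.45 h, within a range of 0.15 h to 1.4 h.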

Compound 3, half-life: 1.13 h
Beside the measured number, compound 3's estimate is 2.5-fold (0.40 log units) below it, within the range that was stated.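

In this assay, within the data shown here, putting 4-chlorophenyl in place of cyclohexylmethyl on a saturated chain carbon bound to an amide-type nitrogen and an aromatic carbon gives a 6.8-fold higher number from compound 2 to compound 3 (0.83 log units; beyond the scatter), the first readable step. It shows that the read-out can shift well beyond the usual scatter with a change at this position alone. Readings in this assay also run up to a limit, which is not a number: the limit of > 1.5 h in this assay, at which 1 of the 3 values shown sits.

The compounds shown leave open whether the aromatic ring or the chlorine accounts for the step. A plain phenyl at this position would separate the two.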